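Lengthening the triazole side chain on a dihydroxylated ceramide analogue

The source may report more compounds than this note shows. Statements on the series, on what has been measured and on what is new or still open speak of the compounds shown alone.

Of the compounds shown here, three have been measured in a functional assay on HCT-116 cells (Homo sapiens) for cytotoxicity, read by sulforhodamine B assay; on this read-out higher numbers stand for an effect only at larger amounts of compound and lower numbers for an effect already at smaller amounts. Compound 1 `CCCCCCCCCCCCC/C=C/[C@@H](O)[C@H](CO)n1cc(CCCCCC)nn1` gives 12500 nM. Compound 2 `CCCCCCCCCCCCCC[C@@H](O)[C@@H](O)[C@H](CO)n1cc(CCCC)nn1` carries two hydroxyl groups on a fully saturated long chain instead of the alkene of compound 1; in this assay compound 2 gives 12900 nM. Compound 3 `CCCCCCCCCCCCC/C=C/[C@@H](O)[C@H](CO)n1cc(CCC)nn1` gives 16000 nM. Going by the values given here, the one step that joins two of these directly is a 1.3-fold higher number from compound 1 to compound 3 (0.11 log units; within the scatter), a change in the length of the short alkyl arm on the triazole that left the read-out essentially unmoved. Compound 2 stands among these numbers with no separation beyond the scatter from either neighbour: its gaps to compound 1 and to compound 3 are both within the usual spread of repeated measurements.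

Compound 4 `CCCCCCCCCCCCCC[C@@H](O)[C@@H](O)[C@H](CO)n1cc(CCCCCCCCCCCCC)nn1` differs from compound 2 by nonyl in place of hydrogen on a saturated chain carbon, four bonds along the chain from an aromatic carbon. Among the compounds with values here, the only measured step that bears on this change, the shortening of the same arm from compound 1 to compound 3, was within the scatter, though it moved the arm by far fewer carbons than the present extension. With no other guidance, the expected step from compound 2 to compound 4 is a 1.1-fold lower number from compound 2 to compound 4 (0.03 log units; within the scatter), that is, no change beyond the scatter is anticipated. Compound 4 is therefore estimated at 12000 nM, with a likely range from 4500 nM to 32000 nM.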

Compound 4, half-maximal effective concentration: > 50000 nM
Compound 4: only a limit was reported; the forecaster's own chance of this, stated with the estimate: 5%; middle value at least 4.1-fold (0.61 log units) away from the limit.
By their numbers in this assay, from the lowest: compounds 1, 2 and 3 (each within the scatter of the next). At a limit, above all of these: compound 4.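

Putting nonyl in place of hydrogen on a saturated chain carbon, four bonds along the chain from an aromatic carbon, gives an at least 3.8-fold higher number from compound 2 to compound 4 (0.58 log units; beyond the scatter) in this assay. Going by these compounds alone, the only earlier step at this arm, a 1.3-fold higher number from compound 1 to compound 3 (0.11 log units; within the scatter), showed a small change in its length with no effect beyond the scatter, whereas this much larger extension shows that the read-out can respond to a change at this position. The true size of the new step remains unknown, since compound 4 reads only as a limit and not as a number: the limit of > 50000 nM in this assay, at which 1 of the 4 values shown sits.

The compounds shown leave open at what chain length the read-out begins to rise on the core of compound 2, which an octyl arm would help to narrow down, and whether a chain of similar length ending in an amine or a carboxylic acid would behave in the same way. They also leave open whether the same nonyl extension would have a comparable effect on the alkene-bearing core of compound 1.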